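Triazole substituent change in the shared core series

The source may hold more compounds than are shown below. What is called first, only, known or untested is meant among the compounds shown, and "the series" means these compounds.

In a functional assay on SW-620 cells (Homo sapiens) for antiproliferative activity, read by MTT assay, with a stated time of 72 h (on this read-out lower numbers stand for stronger inhibition and higher numbers for weaker inhibition), compound 2 `O=C1O[C@H]([C@@H](O)Cn2cc(C3CC3)nn2)C(OCc2ccccc2)=C1OCc1ccccc1` gives 54200 nM, the upper of the two numbers recorded so far. Compound 1 `O=C1O[C@H]([C@@H](O)Cn2cc(-c3cc(C(F)(F)F)cc(C(F)(F)F)c3)nn2)C(OCc2ccccc2)=C1OCc1ccccc1` gives 49200 nM in this assay, a gap from compound 2 that lies within the scatter. Compound 3 `O=C1O[C@H]([C@@H](O)Cn2cc(CCO)nn2)C(OCc2ccccc2)=C1OCc1ccccc1` differs from compound 2 in one place: 2-hydroxyethyl in place of cyclopropyl on an aromatic carbon. Within the data shown here, no step between measured compounds informs this change, so no shift beyond the scatter is expected in this assay in either direction. Compound 3 is expected to give 60000 nM in this assay, with an estimated range of 25000 nM to 140000 nM. This estimate means an expected step of a 1.1-fold higher number from compound 2 to compound 3 (0.04 log units; within the scatter).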

Compound 3, half-maximal inhibitory concentration: > 100000 nM
Compound 3: a limit, no number; the forecaster's own chance of this, stated with the estimate: 20%; middle value at least 1.6-fold (0.22 log units) away from the limit.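

As far as these compounds go, the change from cyclopropyl to 2-hydroxyethyl on this aromatic carbon gives an at least 1.8-fold higher number from compound 2 to compound 3 (0.26 log units; that floor lies within the scatter) in this assay, so the true size of the step stays unknown. Compound 1 and compound 2 both give numbers, whereas compound 3 is the first in the series to reach a limit of the assay, which is not a number: the limit of > 100000 nM in this assay, at which 1 of the 3 values shown sits.

From the compounds shown here alone, whether an amine, a carboxylic acid or a longer chain ending in hydroxyl at this position also reaches the limit stays open. The compounds shown also do not separate the entering hydroxyl from the loss of the three-membered ring.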